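Compound 1 to compound 3: loss of one methyl

The source may report more compounds than this note shows. Statements on the series, on what has been measured and on what is new or still open speak of the compounds shown alone.

- compound 1 `Cc1ccc(C(=O)Nc2nnc(-c3ccc(O)c(O)c3)s2)cc1` gives 10500 nM
- compound 2 `O=C(Nc1nnc(-c2cccc(O)c2O)s1)c1ccccc1` gives 20700 nM

In a functional assay on HL-60 cells (Homo sapiens) for cytotoxicity, read by MTT assay, with a stated time of 72 h (a higher number here means a weaker inhibitor, a lower number a stronger inhibitor), compound 1 and compound 2 lie within the scatter of each other, so compound 1 holds no separate place on these numbers. Compound 3 `O=C(Nc1nnc(-c2ccc(O)c(O)c2)s1)c1ccccc1` has hydrogen in place of methyl on an aromatic carbon, para to a large group, as counted in hydrogen in place of methyl on an aromatic carbon for the change from compound 1. Going by the values given here, no measured pair shows this change, so no step beyond the scatter is expected in this assay in either direction. The estimated 1.2-fold higher number from compound 1 to compound 3 (0.09 log units; within the scatter) stays within the scatter. For compound 3 the expected value is 13000 nM with an estimated range from 6000 nM to 28000 nM in this assay.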

Compound 3, half-maximal inhibitory concentration: 17600 nM
Estimate against measurement, compound 3: 1.4-fold (0.13 log units) below; the measured number falls inside the stated range.
By their numbers in this assay, from the lowest: compounds 1, 3 and 2 (each within the scatter of the next).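

In this assay, going by these compounds alone, going from 4-methylphenyl to phenyl gives a 1.7-fold higher number from compound 1 to compound 3 (0.22 log units; within the scatter) and is the first direct reading of this change at this position. On an aromatic carbon, para to a large group, hydrogen in place of methyl therefore gives no step beyond the scatter in this pair. No available measurement bears on the reason for this reading.

Going by these compounds, whether an amine, a carboxylic acid or a methoxy group on this carbon would give a step beyond the scatter stays open. The same holds for a longer chain in place of methyl.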